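This account rests on a few compounds, and the source may have more. Where it says the series, first, only, none or still open, it means among the compounds named here.

The measured compounds and their values in a functional assay (Oryctolagus cuniculus) for inhibition of platelet-activating factor receptor (Cavia porcellus) (on this read-out higher numbers stand for weaker inhibition and lower numbers for stronger inhibition), are:

- compound 1, `COc1cc(C(=O)N2CCN(C(=O)c3cc(OC)c(OC)c(OC)c3)C(COC(=O)C3CCCCC3)C2)cc(OC)c1OC`, 290 nM
- compound 2, `COc1cc(C(=O)N2CCN(C(=O)c3cc(OC)c(OC)c(OC)c3)C(COC(=O)NC(C)C(C)(C)C)C2)cc(OC)c1OC`, 170 nM

Compound 2 has the lowest of the two numbers; its nearest neighbour is compound 1, and the step of a 1.7-fold lower number from compound 1 to compound 2 (0.23 log units; within the scatter) lies within the scatter, so no order between the two can be read from these values. Compound 3, `CCCCCN(CCCCC)C(=O)OCC1CN(C(=O)c2cc(OC)c(OC)c(OC)c2)CCN1C(=O)c1cc(OC)c(OC)c(OC)c1`, differs from compound 2 by dipentylamino in place of (1,2,2-trimethylpropyl)amino on a carbonyl carbon. For the measured compounds named here, the single measured step, a 1.7-fold lower number from compound 1 to compound 2 (0.23 log units; within the scatter), also exchanged the group on this carbonyl carbon and stayed within the scatter, so it gives no sign of a direction for the new exchange. Compound 3 is therefore expected to show no step beyond the scatter, a 1.2-fold higher number from compound 2 to compound 3 (0.07 log units; within the scatter). Compound 3 is estimated at 200 nM, with a range from 70 nM to 600 nM.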

Compound 3, half-maximal inhibitory concentration: 11400 nM
Estimate against measurement, compound 3: 57-fold (1.76 log units) below; the whole stated range lies below it.
By their numbers in this assay, from the lowest: compounds 2 and 1 (each within the scatter of the next); then compound 3.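

In this assay, the group on this carbonyl carbon turns out to matter well beyond the scatter: dipentylamino gives a 67-fold higher number from compound 2 to compound 3 (1.83 log units; beyond the scatter) when it replaces (1,2,2-trimethylpropyl)amino and a 39-fold higher number from compound 1 to compound 3 (1.59 log units; beyond the scatter) when it replaces cyclohexyl. The earlier pair gave no sign of such sensitivity, so this position tolerates some groups but not all, and dipentylamino, with 11 heavy atoms and 0 hydrogen-bond donors against 7 heavy atoms and 1 hydrogen-bond donor for the group it replaces in compound 2, is the one that weakens inhibition. No measurement at hand explains this loss.

The exchange changes size and the amide hydrogen together, so the two cannot be separated here. Going by these compounds, whether pentylamino, which keeps that hydrogen, or the shorter dimethylamino would hold inhibition remains open.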